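A few compounds are considered here, and "the series" means these few. Any claim that something is new, unique, unknown or untested is made for them only; others in the source may bear on it.

Of the compounds shown here, three have been measured in an assay on isolated protein for inhibition of Dihydrofolate reductase (Homo sapiens), read by spectrophotometry, using NADPH, with stated times of 5 s and 6 min, tested at 5 uM; a higher number here means a stronger effect of the compound at the concentration tested, a lower number a weaker effect. Compound 1 `NC1=NC2(CCSCC2)N(OCCCOc2ccc(Cl)c(Cl)c2)C(N)=N1` gives 88.4%, compound 2 `CC(C)(C)c1ccc(OCCCON2C(N)=NC(N)=NC23CCSCC3)cc1` gives 85.3%, and compound 3 `NC1=NC2(CCOCC2)N(OCCCOc2ccccc2Cl)C(N)=N1` gives 83.3%. The number for compound 3 lies within the scatter of both compound 2 and compound 1, so the three cannot be told apart on these numbers. Compound 4 `NC1=NC2(CCOCC2)N(OCCCOc2cc(Cl)c(Cl)cc2Cl)C(N)=N1` has not yet been measured. It differs from compound 3 in one place: 2,4,5-trichlorophenyl in place of 2-chlorophenyl on an oxygen on a saturated carbon. Among the measured compounds shown here, no pair of measured compounds isolates this change, so its size cannot be read from the numbers. Since compound 1, which differs from compound 3 in more than one place, still gives a number within the scatter of compound 3, no large swing is expected. For compound 4 the step of a number 3.7 percentage points higher from compound 3 to compound 4 (within the scatter) is expected to be small, with at most a modest rise. Compound 4 is therefore estimated at 87%, within 78% to 95% in this assay.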

Compound 4, a percentage reported as inhibition, at one concentration (the size of the read-out at that concentration, not a potency): > 90%
Compound 4: no number, only a limit (the forecaster's own chance of this, stated with the estimate: 2%); at least 3 percentage points between middle value and limit.
By their numbers in this assay, from the lowest: compounds 3, 2 and 1 (each within the scatter of the next). At a limit, above all of these: compound 4.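

Replacing 2-chlorophenyl with 2,4,5-trichlorophenyl on an oxygen on a saturated carbon gives a number at least 6.7 percentage points higher from compound 3 to compound 4 (that floor lies within the scatter). In this assay compound 4 gives > 90%, which is a limit of the assay and not a number. This is the first change made in one place alone, and it shows that this position accepts the larger group without a loss of effect, though the full size of the step cannot be read because the value stands at a limit: the limit of > 90% in this assay, at which 1 of the 4 values shown sits.

As far as these compounds go, how an amine or a carboxylic acid on the phenyl ring would read remains open. From the compounds shown here alone, the potency of compound 4 also remains open, since this read-out reports a single concentration.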